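Trimming one phenethyl ester toward a smaller methyl ester

The compounds below may be only part of what the source reports. "The series", "measured", "known", "first", "only" and "open" are said of these compounds alone.

Of the compounds shown here, three sharing one core have been tested in an assay on isolated protein for antagonist activity at Voltage-dependent L-type calcium channel subunit alpha-1C (Cavia porcellus), with a stated time of 15 min; on this read-out higher numbers stand for weaker inhibition and lower numbers for stronger inhibition. Compound 1 `CCOC(=O)C1=C(C)NC(C)=C(C(=O)OCC)C1c1csc(-c2ccc(Cl)cc2)n1` gives 3650 nM. Compound 3 `CCOC(=O)C1=C(C)NC(C)=C(C(=O)OCC(C)C)C1c1csc(-c2ccc(Cl)cc2)n1` gives 15400 nM. Compound 2 `CC1=C(C(=O)OCCc2ccccc2)C(c2csc(-c3ccc(Cl)cc3)n2)C(C(=O)OCCc2ccccc2)=C(C)N1` gives 500000 nM, the highest of the three numbers, beyond the scatter from both others. Within the data shown here, the one single-point step among the measured compounds is a 4.2-fold higher number from compound 1 to compound 3 (0.63 log units; beyond the scatter), so enlarging an ester group here went with weaker inhibition.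

Compound 4 `COC(=O)C1=C(C)NC(C)=C(C(=O)OCCc2ccccc2)C1c1csc(-c2ccc(Cl)cc2)n1` is the unmeasured compound. It differs from compound 2 in this way: hydrogen in place of benzyl on a saturated chain carbon bound to an oxygen next to a carbonyl group. That change shrinks one of the two ester groups considerably, the reverse direction of the enlargement seen in the measured step, so a clearly lower number in this assay is expected for compound 4, although the remaining phenethyl ester likely keeps it short of compound 1. The step from compound 2 to compound 4 is expected to be a 17-fold lower number from compound 2 to compound 4 (1.22 log units; beyond the scatter). Compound 4 is therefore estimated at 30000 nM, with a range from 8000 nM to 120000 nM.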

Compound 4, half-maximal inhibitory concentration: 10200 nM
Compound 4: middle estimate off by 2.9-fold (0.47 log units), on the high side; measured number inside the range.
By their numbers in this assay, from the lowest: compound 1; then compounds 4 and 3 (each within the scatter of the next); then compound 2.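

Changing one phenethyloxycarbonyl group to methoxycarbonyl gives a 49-fold lower number from compound 2 to compound 4 (1.69 log units; beyond the scatter) in this assay, a large step that shows this ester position can respond strongly to removing a benzyl group. The earlier compounds shown here offered only a modest step in the opposite direction, a 4.2-fold higher number from compound 1 to compound 3 (0.63 log units; beyond the scatter), so the trend now holds for both enlarging and cutting back an ester chain, though across only these two pairs and on different partner esters. No measurement here explains why this change has so large an effect.

Whether a single remaining phenethyl ester costs anything remains open, since no compound shown pairs a methyl ester with a second methyl ester or with an ethyl ester. It is also unknown how a propyl chain, or a carboxylic acid in place of the methoxycarbonyl group, would behave at this position.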